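This account rests on a few compounds, and the source may have more. Where it says the series, first, only, none or still open, it means among the compounds named here.

The series keeps one shared core and varies only the aryl group on an amide-type nitrogen. Among the compounds with values here, compound 1 `COc1cccc(NC(=O)Nc2ccc(Nc3ncnc4c3OCCN4)cc2)c1` carries a 3-methoxyphenyl there; in an assay on isolated protein for inhibition of proto-oncogene tyrosine-protein kinase receptor Ret (Homo sapiens), read by 33P incorporation, with stated times of 15 min and 40 min (a higher number here means a weaker inhibitor, a lower number a stronger inhibitor), compound 1 gives 6810 nM, the highest of the three numbers measured so far. Compound 2 `Cc1ccc(F)c(NC(=O)Nc2ccc(Nc3ncnc4c3OCCN4)cc2)c1` gives 1470 nM in this assay, and compound 3 `Cc1cc(C)cc(NC(=O)Nc2ccc(Nc3ncnc4c3OCCN4)cc2)c1` gives 1070 nM. Both measured steps away from compound 1 lower the number: a 4.6-fold lower number from compound 1 to compound 2 (0.67 log units; beyond the scatter) and a 6.4-fold lower number from compound 1 to compound 3 (0.80 log units; beyond the scatter). The step of a 1.4-fold lower number from compound 2 to compound 3 (0.14 log units; within the scatter) lies within the scatter.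

Compound 4 `O=C(Nc1ccc(Nc2ncnc3c2OCCN3)cc1)Nc1cccc(-c2ccccc2)c1` has not yet been measured. It differs from compound 1 by phenyl in place of methoxy on an aromatic carbon, meta to a large group. Both measured departures from compound 1 bear on this change because a 4.6-fold lower number from compound 1 to compound 2 (0.67 log units; beyond the scatter) and a 6.4-fold lower number from compound 1 to compound 3 (0.80 log units; beyond the scatter) each also remove the methoxy of compound 1, and each was modest in size. Within the data shown here, no measured compound shows how a phenyl in that place behaves. The expected step is therefore modest and downward in this assay, a 4.5-fold lower number from compound 1 to compound 4 (0.66 log units; beyond the scatter), though a step within the scatter cannot be excluded. Compound 4 is estimated at 1500 nM in this assay, with a range from 500 nM to 5000 nM.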

Compound 4, half-maximal inhibitory concentration: > 10000 nM
Compound 4: no number, only a limit (the forecaster's own chance of this, stated with the estimate: 2%); middle value at least 6.6-fold (0.82 log units) from the limit.
By their numbers in this assay, from the lowest: compounds 3 and 2 (each within the scatter of the next); then compound 1. At a limit, above all of these: compound 4.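

Phenyl in place of methoxy, on an aromatic carbon meta to a large group, breaks from the two earlier departures from compound 1, both of which lowered the number in this assay; here the result is an at least 1.4-fold higher number from compound 1 to compound 4 (0.16 log units; that floor lies within the scatter). Taking away the methoxy therefore does not by itself lower the number, and what enters at this position counts: here that is a six-membered aromatic ring of carbon only, with 6 heavy atoms in place of 2. The reading for compound 4 is a limit of the assay and not a number: the limit of > 10000 nM in this assay, at which 1 of the 4 values shown sits.

The true size of the step therefore stays unknown, and only its floor can be read, so the compounds shown leave open how far compound 4 lies from compound 1. As far as these compounds go, they also do not separate the phenyl ring from other groups at this place, and it remains open whether an ethyl, a cyclopropyl, a pyridyl or an amine there would lower the number or raise it.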